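Replacing pyridin-3-yl on the carbonyl carbon of compound 2

A few compounds are considered here, and "the series" means these few. Any claim that something is new, unique, unknown or untested is made for them only; others in the source may bear on it.

In a physicochemical assay for solubility (on this read-out lower numbers stand for lower solubility and higher numbers for higher solubility), compound 1 (`O=C(c1ccc(Cl)cc1)N1CCC(NS(=O)(=O)c2cc(S(=O)(=O)c3ccccc3)ccc2C(F)(F)F)CC1`) gives 3100 nM and compound 2 (`O=C(c1cccnc1)N1CCC(NS(=O)(=O)c2cc(S(=O)(=O)c3ccccc3)ccc2C(F)(F)F)CC1`) gives 50000 nM as the highest of the two numbers. Compound 3 (`CC(C)(C)OC(=O)N1CCC[C@H]1C(=O)N1CCC(NS(=O)(=O)c2cc(S(=O)(=O)c3ccccc3)ccc2C(F)(F)F)CC1`) has 1-(tert-butoxycarbonyl)pyrrolidin-2-yl in place of pyridin-3-yl on a carbonyl carbon. Among the compounds with values here, the one measured step at that place (a 16-fold higher number from compound 1 to compound 2 (1.21 log units; beyond the scatter)) was large and beyond the scatter, so a sizeable move is possible, and with only that step to go on, a fall from the top number is expected. The expected step (a 6.3-fold lower number from compound 2 to compound 3 (0.80 log units; beyond the scatter)) is a drop. In this assay compound 3 is estimated at 8000 nM (expected range 2000 nM to 30000 nM).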

Compound 3, solubility: 25000 nM
The estimate for compound 3 lay 3.1-fold (0.49 log units) below the measured number; measured number inside the range.
By their numbers in this assay, from the lowest: compound 1; then compounds 3 and 2 (each within the scatter of the next).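

In this assay, 1-(tert-butoxycarbonyl)pyrrolidin-2-yl in place of pyridin-3-yl on the carbonyl carbon gives a 2.0-fold lower number from compound 2 to compound 3 (0.30 log units; within the scatter), so this position accepts a larger, non-aromatic group with no step beyond the scatter. Set against 4-chlorophenyl, the same group gives an 8.1-fold higher number from compound 1 to compound 3 (0.91 log units; beyond the scatter), which shows that a step of this kind from compound 1 is not confined to pyridin-3-yl. Nothing measured here accounts for either step.

The compounds shown leave open whether a free pyrrolidin-2-yl amine, without the tert-butoxycarbonyl group, or the opposite stereocentre would stand at a similar number.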